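Link between the core and the dichlorinated ring: compound 4

This account rests on a few compounds, and the source may have more. Where it says the series, first, only, none or still open, it means among the compounds named here.

Measured compounds in an assay on CHO cells, read by calcium flux; a lower number here means a stronger inhibitor, a higher number a weaker inhibitor:
compound 1 `O=C(Nc1ccc(C(F)(F)F)cc1)c1csc(Cc2c(Cl)cccc2Cl)n1` gives 88 nM
compound 2 `O=C(Nc1ccc(C(F)(F)F)cc1)c1cnc(Cc2c(Cl)cccc2Cl)s1` gives 1780 nM
compound 3 `O=C(Nc1ccc(C(F)(F)F)cc1)c1csc(-c2c(Cl)cccc2Cl)n1` gives > 4000 nM

Compound 3 stands at the limit (the limit of > 4000 nM in this assay, at which 1 of the 3 values shown sits); its value in this assay is a limit of the assay and not a number. Compound 1 and compound 2 give numbers in this assay, and compound 1 sits at the lower end of the three.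

The step to compound 4 `O=C(Nc1ccc(C(F)(F)F)cc1)c1csc(Nc2c(Cl)cccc2Cl)n1` is (2,6-dichlorophenyl)amino in place of 2,6-dichlorophenyl on an aromatic carbon.

Among the compounds with values here, the one measured step that bears on this place is an at least 45-fold higher number from compound 1 to compound 3 (1.65 log units; beyond the scatter), which is large and beyond the scatter. Within the data shown here, no measured step covers the (2,6-dichlorophenyl)amino group itself, so its effect is uncertain. The amino group, like the benzyl of compound 1, sets the dichlorinated ring one position further from the core than in compound 3, so a return toward the number of compound 1 is plausible but not assured.

Compound 4 is therefore expected to give 500 nM in this assay, with a range of 90 nM to 3500 nM. The expected step is an at least 8.0-fold lower number from compound 3 to compound 4 (0.90 log units; beyond the scatter), a decrease in the number, though a reading at the limit remains possible.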

Compound 4, half-maximal inhibitory concentration: 48 nM
Beside the measured number, compound 4's estimate is 10-fold (1.02 log units) above it, and the stated range ends above it.
By their numbers in this assay, from the lowest: compounds 4 and 1 (each within the scatter of the next); then compound 2. At a limit, above all of these: compound 3.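

In this assay, placing the amino link on this aromatic carbon gives an at least 83-fold lower number from compound 3 to compound 4 (1.92 log units; beyond the scatter), so the directly attached 2,6-dichlorophenyl of compound 3 is not the limiting feature of the dichlorinated ring at this position. Compound 3 stands at a limit and not a number, so that step is only a bound: the limit of > 4000 nM in this assay, at which 1 of the 4 values shown sits. The benzyl and amino links cannot be told apart in this assay, with a 1.8-fold lower number from compound 1 to compound 4 (0.26 log units; within the scatter), so this position accepts either a carbon or a nitrogen link with no difference beyond the scatter.

Going by these compounds, whether an ether oxygen, a methylamino link or a longer chain would read like these two links remains open. Also open, on these data alone, is whether the amino link would behave the same way on the core of compound 2.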